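The compounds below may be only part of what the source reports. "The series", "measured", "known", "first", "only" and "open" are said of these compounds alone.

Measured so far:
compound 1 `CC(=O)Cn1nnc(Cc2ccc(-c3ccccc3)cc2)n1` — in a functional assay on HEK293 cells for agonist activity at transient receptor potential cation channel subfamily V member 1 (Homo sapiens), read by calcium flux (on this read-out lower numbers stand for an effect already at smaller amounts and higher numbers for an effect only at larger amounts of compound), compound 1 gives > 100000 nM, which is a limit of the assay.
compound 2 `CC(C)Cn1nnc(Cc2ccc(-c3ccccc3)cc2)n1` — in this assay compound 2 gives 10000 nM.
compound 3 `CC(=O)Cn1nnc(CNC(=O)c2ccc(-c3ccccc3)cc2)n1` — in this assay compound 3 gives > 100000 nM, again a limit and not a number.

The change isopropyl in place of acetyl on a saturated chain carbon bound to an aromatic nitrogen produced an at least 10-fold lower number from compound 1 to compound 2 (1.00 log units; beyond the scatter). Note (the limit of > 100000 nM in this assay, at which 2 of the 3 values shown sit), so the series is thin on numbers. Compound 4 `CC(C)Cn1nnc(CNC(=O)c2ccc(-c3ccccc3)cc2)n1` carries the same change on the core of compound 3, namely (isopropyl in place of acetyl on a saturated chain carbon bound to an aromatic nitrogen); the place is the same word for word. How the core of compound 3 differs from that of compound 1 is not broken down here. Since compound 3 shows only a limit, the step of an at least 2.0-fold lower number from compound 3 to compound 4 (0.30 log units; that floor lies within the scatter) is expected to mirror the earlier one only loosely. Compound 4 is estimated at 50000 nM, within 10000 nM to 200000 nM, with a real chance that compound 4 again returns only a limit.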

Compound 4, half-maximal effective concentration: 53500 nM
Compound 4: middle estimate off by 1.1-fold (0.03 log units), on the low side; measured number inside the range.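

In this assay the same change on the second core gives an at least 1.8-fold lower number from compound 3 to compound 4 (0.27 log units; that floor lies within the scatter). On these data alone, compound 3 gives > 100000 nM, which is a limit and not a number, so the true size of this step remains unknown. The result fits a change that carries over from one core to the other, but it does not show that the change has the same size on both: the same change on two cores in this assay, an at least 10-fold lower number (1.00 log units; beyond the scatter) from compound 1 to compound 2 and an at least 1.8-fold lower number (0.27 log units; that floor lies within the scatter) from compound 3 to compound 4; the limit leaves it open whether they differ.

Open, as far as these compounds go, is what an amine, a carboxylic acid or a longer chain would give in place of isopropyl on a saturated chain carbon bound to an aromatic nitrogen, on either core. Also open, from the compounds shown here alone, is how far any step can be sized, with so many values at a limit: the limit of > 100000 nM in this assay, at which 2 of the 4 values shown sit.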